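The source may report more compounds than this note shows. Statements on the series, on what has been measured and on what is new or still open speak of the compounds shown alone.

Measured so far in a functional assay on MCF7 cells (Homo sapiens) for cytotoxicity, read by MTT assay, with a stated time of 48 h; on this read-out higher numbers stand for weaker inhibition and lower numbers for stronger inhibition:

Compound 1 `C/C(=N\NC(=S)Nc1cccc([N+](=O)[O-])c1)c1ccccn1` gives 38 nM.
Compound 2 `C/C(=N\NC(=S)Nc1ccc(F)cc1)c1ccccn1` gives 1.2 nM.
Compound 3 `C/C(=N\NC(=S)Nc1ccccc1F)c1ccccn1` gives 0.39 nM.

Among these three, compound 3 has the lowest number, and therefore the strongest inhibition; its gap to compound 2 and its far larger gap to compound 1 both lie beyond the usual scatter. The next compound, compound 4 `C/C(=N\NC(=S)Nc1ccccc1)c1ccccn1`, has not yet been measured. Its difference from compound 3 is a small one: hydrogen in place of fluoro on an aromatic carbon.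

Among the measured compounds shown here, with no measured pair showing this exact change, the expectation for compound 4 rests on the three numbers above. A modest step toward a higher number is expected, a 2.6-fold higher number from compound 3 to compound 4 (0.41 log units; beyond the scatter), leaving compound 4 still among the stronger inhibitors. The estimate for compound 4 is 1 nM, expected to fall between 0.25 nM and 4 nM.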

Compound 4, half-maximal inhibitory concentration: 0.18 nM
Compound 4: the middle estimate sits 5.6-fold (0.74 log units) above what was measured; the measured number lies below the stated range.
By their numbers in this assay, from the lowest: compound 4; then compound 3; then compound 2; then compound 1.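

In this assay, hydrogen in place of fluoro ortho to a large group gives a 2.2-fold lower number from compound 3 to compound 4 (0.34 log units; beyond the scatter), so fluoro at this position is not needed for strong inhibition. The same exchange at the fluoro position of the other fluoro compound gives a 6.7-fold lower number from compound 2 to compound 4 (0.82 log units; beyond the scatter), and hydrogen in place of nitro gives a 210-fold lower number from compound 1 to compound 4 (2.32 log units; beyond the scatter), so all three substituents shown carry higher numbers than hydrogen. No measurement shown explains these steps. From the compounds shown here alone, whether a methyl group or an amine at this position would also give a higher number remains open.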